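Adding a Fluorine to a Second Alkyne-Linked Core

The compounds below may be only part of what the source reports. "The series", "measured", "known", "first", "only" and "open" are said of these compounds alone.

Compound 1 `Fc1cccc(F)c1C#Cc1nccc2ccccc12` and compound 2 `Fc1ccc2ccnc(C#Cc3c(F)cccc3F)c2c1` share one core. In a functional assay on LS174T cells (Homo sapiens) for inhibition, with a stated time of 4 days, tested at 10 uM (a lower number here means a weaker effect, a higher number a stronger effect of the compound at the concentration tested), compound 1 gives 96.7%, and compound 2 gives 96.2%. The step of a number 0.5 percentage points lower from compound 1 to compound 2 (within the scatter) comes from the change (fluoro in place of hydrogen on an aromatic carbon).

Compound 3 `Fc1cccc(F)c1C#Cc1cnc2ccccc2c1` is built from the same atoms as compound 1, joined differently; how the two cores differ is not broken down here. In this assay compound 3 gives 90.4%.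

Compound 4 `Fc1cccc(F)c1C#Cc1cnc2c(F)cccc2c1` arises from compound 3 by fluoro in place of hydrogen on an aromatic carbon. This is the same kind of change as that from compound 1 to compound 2, but the place differs: in compound 4 the fluoro sits ortho to a fused ring and meta to a fused ring, whereas in compound 2 it sits meta to a fused ring and para to a fused ring. Because a number 0.5 percentage points lower from compound 1 to compound 2 (within the scatter) left the read-out essentially unchanged, the step of a number 0.4 percentage points lower from compound 3 to compound 4 (within the scatter) is expected to be small as well. Compound 4 is therefore estimated to give 90% in this assay.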

Compound 4, a percentage reported as inhibition, at one concentration (the size of the read-out at that concentration, not a potency): 89.1%
The estimate for compound 4 lay 0.9 percentage points above the measured number; the range from low to high includes it.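

In this assay, putting fluoro in place of hydrogen on an aromatic carbon of the core of compound 3 gives a step of a number 1.3 percentage points lower from compound 3 to compound 4 (within the scatter). Set beside the earlier case, the change behaves alike on the two cores: the same change on two cores in this assay, a number 0.5 percentage points lower (within the scatter) from compound 1 to compound 2 and a number 1.3 percentage points lower (within the scatter) from compound 3 to compound 4, 0.8 percentage points apart, within the scatter of two such steps. This shows that in these two pairs, at different places on two cores, the change leaves the read-out within the scatter, but two pairs read at a single concentration show neither a general rule nor anything about potency.

The compounds shown leave open whether an amine or a methoxy group in the same place would match fluoro. They also leave open how fluoro behaves elsewhere on these cores.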